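Ring-nitrogen aryl variation in the thiazolidinone amide series

This account rests on a few compounds, and the source may have more. Where it says the series, first, only, none or still open, it means among the compounds named here.

Three compounds share one core and differ only in the aryl group on the amide-type nitrogen of the five-membered ring. In a functional assay on U2OS cells (Homo sapiens) for inhibition, read by CCK-8 assay, with a stated time of 72 h, tested at 1 uM (a higher number here means more inhibition at the concentration tested (going by the name of the read-out), a lower number less inhibition), compound 1 `COc1ccc(C)cc1N1C(=O)CSC1c1cccc(C(=O)NCCCCc2ccccc2)c1` gives 30%. Compound 2 `COc1cc(F)ccc1N1C(=O)CSC1c1cccc(C(=O)NCCCCc2ccccc2)c1` gives 34% in this assay, and the step of a number 4 percentage points higher from compound 1 to compound 2 (within the scatter) lies within the scatter. Compound 3 `COc1c(F)cccc1N1C(=O)CSC1c1cccc(C(=O)NCCCCc2ccccc2)c1` gives 12%, the lowest of the three numbers; the steps of a number 18 percentage points lower from compound 1 to compound 3 (beyond the scatter) and a number 22 percentage points lower from compound 2 to compound 3 (beyond the scatter) both lie beyond the scatter and are modest in size.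

Compound 4 `O=C(NCCCCc1ccccc1)c1cccc(C2SCC(=O)N2c2ccccc2F)c1` has not been measured. Relative to compound 3 the change is 2-fluorophenyl in place of 3-fluoro-2-methoxyphenyl on an amide-type nitrogen in a ring. Among the measured compounds shown here, the steps that bear on it are the three aryl changes on this nitrogen: one within the scatter, two modest. For the measured compounds named here, none of the measured compounds lacks the methoxy group, so the effect of its removal is not anchored by any measured pair. A modest step in either direction is therefore plausible; on balance compound 4 is expected to sit near the middle of the measured numbers, giving an expected step of a number 10 percentage points higher from compound 3 to compound 4 (within the scatter). The estimate for compound 4 in this assay is 22%, with a range from 5% to 40%.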

Compound 4, a percentage reported as inhibition, at one concentration (the size of the read-out at that concentration, not a potency): 38%
The estimate for compound 4 lay 16 percentage points below the measured number; the measured number falls inside the stated range.
By their numbers in this assay, from the lowest: compound 3; then compounds 1, 2 and 4 (each within the scatter of the next).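

In this assay, the 2-fluorophenyl group gives the series its first anchor for an aryl group on this nitrogen without a methoxy group, at a number 26 percentage points higher from compound 3 to compound 4 (beyond the scatter), so a methoxy group is not required for a number on the level of compounds 1 and 2. The steps of a number 4 percentage points higher from compound 2 to compound 4 (within the scatter) and a number 8 percentage points higher from compound 1 to compound 4 (within the scatter) leave compounds 1, 2 and 4 as one band with compound 3 alone apart from it, and so among these compounds neither the methoxy group (present in compounds 1 and 2) nor a fluorine on the aryl ring (present in compounds 2 and 4) goes with the low number by itself; it is seen only with the 3-fluoro-2-methoxyphenyl group. No supporting data on why the numbers fall this way are available for this change.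

From the compounds shown here alone, what a plain phenyl, a 2-chlorophenyl, a pyridyl ring or an aryl group bearing an amine or a carboxylic acid would give on this nitrogen remains open. Also open, going by these compounds, is whether the band of compounds 1, 2 and 4 would hold at other concentrations, since these numbers are sizes of the read-out at one concentration and not potencies.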